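A few compounds are considered here, and "the series" means these few. Any claim that something is new, unique, unknown or untested is made for them only; others in the source may bear on it.

Working notes on the series.

Compound 1 `CCCS(=O)(=O)N1CCC(CNC(=O)c2ccc(Cl)cc2Cl)(C(=O)N2CC(N)C2)CC1` gives 109 nM in an assay on isolated protein for inhibition of sodium- and chloride-dependent glycine transporter 1 (Homo sapiens); on this read-out lower numbers stand for stronger inhibition and higher numbers for weaker inhibition. Compound 2 `CCCS(=O)(=O)N1CCC(CNC(=O)c2c(F)cccc2F)(C(=O)N2CCOCC2)CC1` gives 131 nM in this assay, and compound 3 `CCCS(=O)(=O)N1CCC(CNC(=O)c2c(F)ccc(Cl)c2F)(C(=O)N2CCOCC2)CC1` gives 8.4 nM. Compound 1 thus stands second highest of the three numbers; its value and that of compound 2 lie within the scatter of each other, while compound 3 lies well below it, beyond the scatter. For the measured compounds named here, the one single-point step measured so far is a 16-fold lower number from compound 2 to compound 3 (1.19 log units; beyond the scatter), which concerns chloro in place of hydrogen on an aromatic carbon.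

Compound 4 `CCCS(=O)(=O)N1CCC(CNC(=O)c2ccc(Cl)cc2Cl)(C(=O)NCC)CC1` has not yet been measured in this assay. It differs from compound 1 in one place: ethylamino in place of 3-aminoazetidin-1-yl on a carbonyl carbon. Going by the values given here, none of the measured steps touches the group on this carbonyl carbon, so the step from compound 2 to compound 3 does not bear on the change at hand, and the series gives no direct guide to its size or direction. Both groups carry one hydrogen-bond donor; the 3-aminoazetidin-1-yl that leaves also carried one hydrogen-bond acceptor, which the ethylamino does not. In the absence of a bearing step, the expected step is a 1.4-fold higher number from compound 1 to compound 4 (0.14 log units; within the scatter), that is, no step beyond the scatter. Compound 4 is therefore estimated at 150 nM, with a range from 50 nM to 450 nM.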

Compound 4, half-maximal inhibitory concentration: 517 nM
Beside the measured number, compound 4's estimate is 3.4-fold (0.54 log units) below it; the whole stated range lies below it.
By their numbers in this assay, from the lowest: compound 3; then compounds 1 and 2 (each within the scatter of the next); then compound 4.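

In this assay, for the compounds shown here, the first measured change at this carbonyl carbon gives a 4.7-fold higher number from compound 1 to compound 4 (0.68 log units; beyond the scatter), so the number here responds to the group on the carbonyl, which the earlier compounds could not show. The hydrogen-bond donor count stays the same across this change, while the four-membered ring and the hydrogen-bond acceptor leave, along with some heavy atoms; keeping the donor count alone therefore does not keep the number. Which of these differences matters cannot be told from this single step, and no supporting evidence is available to explain it.

Open, from the compounds shown here alone, is whether the ring or its amine carries the difference: a plain azetidin-1-yl on this carbonyl carbon would separate the two, and a longer chain such as propylamino would show whether the ethylamino result reflects chain size or the loss of the ring. Also open, going by these compounds, is whether a step of this size holds with the aromatic substituents of compound 3 in place of those of compound 1.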